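The source may report more compounds than this note shows. Statements on the series, on what has been measured and on what is new or still open speak of the compounds shown alone.

Compound 1 `COc1ccc(-c2cnc(NC(=O)c3cccc(OC)c3)n2C)cc1` is profiled in a toxicity assay on THP-1 cells (Homo sapiens) for inhibition; a lower number here means that less compound is tolerated, a higher number that more compound is tolerated. In this assay compound 1 reaches only a limit, > 100000 nM, so its standing is a bound rather than a number (the limit of > 100000 nM in this assay, at which 1 of the 2 values shown sits). Compound 2 `COc1ccccc1-c1cnc(NC(=O)c2ncc[nH]2)n1C` likewise gives only a limit in this assay, > 50000 nM, again a bound (the limit of > 50000 nM in this assay, at which 1 of the 2 values shown sits). For the measured compounds named here, no step between measured compounds is therefore available. Compound 3 `COc1ccc(-c2cnc(NC(=O)c3ccc(F)cc3)n2C)cc1` differs from compound 1 in one place: 4-fluorophenyl in place of 3-methoxyphenyl on a carbonyl carbon. For this change no step beyond the usual scatter is expected in this assay, in either direction. Compound 3 is expected to give 100000 nM in this assay, within 30000 nM to 300000 nM, an expected step of a number no higher from compound 1 to compound 3 (the limit leaves the size open).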

Compound 3, half-maximal cytotoxic concentration: >= 50000 nM
Compound 3 was reported as a limit; the forecaster's own chance of this, stated with the estimate: 70%; the middle value lies beyond the limit too.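

Compound 1 and compound 3 are both reported only as limits in this assay, and no step can be read between them. The compounds shown leave open the concentration at which any of them turns cytotoxic, and whether 4-fluorophenyl in place of 3-methoxyphenyl shifts it.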